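A few compounds are considered here, and "the series" means these few. Any claim that something is new, unique, unknown or untested is made for them only; others in the source may bear on it.

Measured so far in a functional assay on KG-1 cells (Homo sapiens) for cytotoxicity, read by luminescence and CellTiter-Glo, with a stated time of 3 days; on this read-out lower numbers stand for stronger inhibition and higher numbers for weaker inhibition
compound 1 `Cc1cc(C#N)ccc1NC(=O)c1ccc2cccnc2c1O` gives 3240 nM here
compound 2 `COc1ccc(C(=O)Nc2ccc(C#N)cc2)c(O)c1` gives 5430 nM here
compound 3 `O=C(Nc1ccc([N+](=O)[O-])cc1Cl)c1cc(F)ccc1O` gives 490 nM here

Compound 2 and compound 1 lie within the scatter of each other, so compound 2 stands with compound 1 at the high end of this small set. Compound 3 has a clearly lower number than compound 2, beyond the scatter.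

Compound 4 `N#Cc1ccc(NC(=O)c2ccc(-c3ccncc3)cc2O)cc1` carries pyridin-4-yl in place of methoxy on an aromatic carbon, meta to a hydroxy group and para to a large group (pyridin-4-yl in place of methoxy on an aromatic carbon). Going by the values given here, no measured pair differs in one place, so this change has no direct precedent here. In this assay a small move towards a lower number is expected, possibly none beyond the scatter. The expected step of a 2.2-fold lower number from compound 2 to compound 4 (0.34 log units; beyond the scatter) remains uncertain in size. For compound 4 the estimated value is 2500 nM with an expected range from 700 nM to 8000 nM in this series.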

Compound 4, half-maximal inhibitory concentration: 8840 nM
Beside the measured number, compound 4's estimate is 3.5-fold (0.55 log units) below it; measured number above the stated range.
By their numbers in this assay, from the lowest: compound 3; then compounds 1, 2 and 4 (each within the scatter of the next, the first and the last beyond it).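

Going by these compounds alone, the read in this assay is a 1.6-fold higher number from compound 2 to compound 4 (0.21 log units; within the scatter) for pyridin-4-yl in place of methoxy on this aromatic carbon, the first comparison that differs in one place. At this position, the six-heavy-atom ring and the two-heavy-atom methoxy therefore leave the two compounds within the scatter of each other. No measurement available here bears on this result.

Still open, on these data alone, is whether an amine, a carboxylic acid or a longer alkoxy chain on this carbon would give a step beyond the scatter. As far as these compounds go, whether pyridin-4-yl would read the same on the core of compound 3 is also open.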